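This account rests on a few compounds, and the source may have more. Where it says the series, first, only, none or still open, it means among the compounds named here.

Measured in a functional assay on A549 cells (Homo sapiens) for antiproliferative activity, read by MTT assay, with a stated time of 72 h; a lower number here means a stronger inhibitor, a higher number a weaker inhibitor:
- compound 1 `COc1cc(F)c(NC(=O)c2ccncc2)cc1Nc1nccc(-c2cn(C)c3ccccc23)n1` gives 4200 nM
- compound 2 `COc1cc(F)c(NC(=O)c2ccnc(Cl)c2)cc1Nc1nccc(-c2cn(C)c3ccccc23)n1` gives 6890 nM
- compound 3 `COc1cc(F)c(NC(=O)c2ccnc(O)c2)cc1Nc1nccc(-c2cn(C)c3ccccc23)n1` gives 11700 nM

In this assay compound 3 carries the highest of the three numbers. Its nearest neighbour is compound 2: a 1.7-fold higher number from compound 2 to compound 3 (0.23 log units; within the scatter). Against compound 1 the gap is larger: a 2.8-fold higher number from compound 1 to compound 3 (0.44 log units; beyond the scatter), a modest step.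

Compound 4 `COc1cc(F)c(NC(=O)c2ccncc2OC)cc1Nc1nccc(-c2cn(C)c3ccccc23)n1` differs from compound 3 in one place: 3-methoxypyridin-4-yl in place of 2-hydroxypyridin-4-yl on a carbonyl carbon. Among the compounds with values here, no measured pair shows this exact exchange. Within the data shown here, the steps that bear on it are the hydroxy step, a 2.8-fold higher number from compound 1 to compound 3 (0.44 log units; beyond the scatter), which compound 4 undoes, and the two substituent steps, a 1.6-fold higher number from compound 1 to compound 2 (0.21 log units; within the scatter) and a 1.7-fold higher number from compound 2 to compound 3 (0.23 log units; within the scatter), both within the scatter. Among the measured compounds shown here, the methoxy group itself has no precedent among the measured compounds. On this basis a small step back toward the number of compound 1 is expected, a 2.0-fold lower number from compound 3 to compound 4 (0.29 log units; within the scatter), possibly no larger than the scatter. Compound 4 is therefore expected to give about 6000 nM, with a range from 2500 nM to 14000 nM.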

Compound 4, half-maximal inhibitory concentration: 3430 nM
The estimate for compound 4 lay 1.7-fold (0.24 log units) above the measured number, and the stated range covers the measured number.
By their numbers in this assay, from the lowest: compounds 4, 1, 2 and 3 (each within the scatter of the next, the first and the last beyond it).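

In this assay, a substituent with oxygen on this pyridine no longer has to cost activity: the hydroxy compound stood beyond the scatter from compound 1, but the methoxy compound does not (a 1.2-fold lower number from compound 1 to compound 4 (0.09 log units; within the scatter)). Exchanging 2-hydroxypyridin-4-yl for 3-methoxypyridin-4-yl on the carbonyl carbon gives a step beyond the scatter (a 3.4-fold lower number from compound 3 to compound 4 (0.53 log units; beyond the scatter)), whereas the exchange for 2-chloropyridin-4-yl does not separate the two compounds (a 2.0-fold lower number from compound 2 to compound 4 (0.30 log units; within the scatter)). Nothing at hand explains these steps.

This exchange alters both the group and its place on the ring, and a 2-methoxypyridin-4-yl or 3-hydroxypyridin-4-yl compound would separate the two. As far as these compounds go, how an amine or a longer ether such as ethoxy would read on this ring also remains open.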